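Chloro-for-hydrogen step carried onto the core of compound 3

The source may hold more compounds than are shown below. What is called first, only, known or untested is meant among the compounds shown, and "the series" means these compounds.

Measured so far:
Compound 1 `ClCc1ccccc1Cn1cnc2c(Cl)nc(Cl)nc21`: 720 nM
Compound 2 `ClCc1ccccc1Cn1cnc2c(Cl)ncnc21`: 3380 nM
Compound 3 `ClCc1cccc(Cn2cnc3ncnc(Cl)c32)c1`: 7070 nM

All three were run in a functional assay on SN12C cells (Homo sapiens) for cytotoxicity, read by sulforhodamine B assay, with a stated time of 48 h; a lower number here means a stronger inhibitor of growth, a higher number a weaker inhibitor of growth. Compound 3 gives the highest number of the three; the difference between its core and the core of compound 2 is not broken down here. From compound 2 to compound 1 the change is chloro in place of hydrogen on an aromatic carbon, with a step of a 4.7-fold lower number from compound 2 to compound 1 (0.67 log units; beyond the scatter) in this assay.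

Compound 4 `ClCc1cccc(Cn2cnc3nc(Cl)nc(Cl)c32)c1` is not yet measured. It differs from compound 3 by chloro in place of hydrogen on an aromatic carbon, the same change at the same place as between compound 2 and compound 1. Within the data shown here, the step from compound 3 to compound 4 in this assay is expected to be a 4.2-fold lower number from compound 3 to compound 4 (0.62 log units; beyond the scatter), resting on the one earlier instance of this change, a 4.7-fold lower number from compound 2 to compound 1 (0.67 log units; beyond the scatter). Compound 4 is estimated at 1700 nM, with a range from 600 nM to 4500 nM.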

Compound 4, concentration for 50% growth inhibition: 1440 nM
Beside the measured number, compound 4's estimate is 1.2-fold (0.07 log units) above it; the range from low to high includes it.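

In this assay, chloro in place of hydrogen on an aromatic carbon, between two ring nitrogen atoms, gives a 4.9-fold lower number from compound 3 to compound 4 (0.69 log units; beyond the scatter). The change carries from the core of compound 2 to the core of compound 3 with a step of much the same size: the same change on two cores in this assay, a 4.7-fold lower number (0.67 log units; beyond the scatter) from compound 2 to compound 1 and a 4.9-fold lower number (0.69 log units; beyond the scatter) from compound 3 to compound 4, 1.0-fold (0.02 log units) apart, within the scatter of two such steps. This rests on two pairs of compounds in a single cell assay, so it gives no cause for the lower number and does not show that the step would hold on a further core.

As far as these compounds go, whether an amine or a methoxy group at this place would give a similar step remains open. So does the effect of replacing the chloromethyl group of compound 1 and compound 4 with a hydroxymethyl group or a longer chain.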